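The compounds below may be only part of what the source reports. "The series", "measured", "known", "first", "only" and "open" are said of these compounds alone.

In a functional assay on A549 cells (Homo sapiens) for inhibition (a higher number here means a weaker inhibitor, a lower number a stronger inhibitor), compound 1 `CN(C(=O)CC(CC(=O)NCCN1CCCC1)c1ccc(Cl)cc1)C1Cc2ccccc2C1` gives 56000 nM, while compound 2 `CCN(CC)CCNC(=O)CC(CC(=O)N(CC)C1Cc2ccccc2C1)c1ccc(Cl)cc1` gives 18400 nM. That is the lower number of the two, and the gap lies beyond the scatter. Compound 3 `CCN(CC)CCNC(=O)CC(CC(=O)N(C)C1Cc2ccccc2C1)c1ccc(Cl)cc1` has not yet been measured. It differs from compound 2 by one small change, hydrogen in place of methyl on a saturated chain carbon bound to an amide-type nitrogen, so that ethyl becomes methyl. Among the measured compounds shown here, no measured pair shows this change alone, so only a small expected step toward a slightly higher number is assumed, a 1.4-fold higher number from compound 2 to compound 3 (0.13 log units; within the scatter), within the scatter. For compound 3 the estimated value is 25000 nM, with a range of 11000 nM to 55000 nM.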

Compound 3, half-maximal inhibitory concentration: 21400 nM
For compound 3 the middle estimate is 1.2-fold (0.07 log units) above the measured one, within the range that was stated.
By their numbers in this assay, from the lowest: compounds 2 and 3 (each within the scatter of the next); then compound 1.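

Ethyl to methyl on a saturated chain carbon bound to an amide-type nitrogen gives a 1.2-fold higher number from compound 2 to compound 3 (0.07 log units; within the scatter) in this assay so the two groups cannot be told apart here. Among the compounds shown here, compound 1 and compound 3 differ in one place only, and diethylamino in place of pyrrolidin-1-yl gives a 2.6-fold lower number from compound 1 to compound 3 (0.42 log units; beyond the scatter) as the one step beyond the scatter. Nothing measured here explains that step.

From the compounds shown here alone, whether propyl in place of ethyl would also stay within the scatter remains open. So does how piperidin-1-yl or morpholin-4-yl would compare with diethylamino.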